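Extending the side chain from propyl to pentyl

This account rests on a few compounds, and the source may have more. Where it says the series, first, only, none or still open, it means among the compounds named here.

Three measured compounds share one core. Compound 1 `CCCCCCCCCCn1cc(-c2nc3ccccc3cc2C)nn1` carries a methyl group; in a functional assay on THP-1 cells (Homo sapiens) for cytotoxicity, read by MTT assay, with a stated time of 24 h (a lower number here means a stronger inhibitor, a higher number a weaker inhibitor), compound 1 returns only a limit, > 100 ug/mL. Compound 2 `CCCCCCCCCCn1cc(-c2nc3ccccc3cc2CC)nn1`, bearing an ethyl group, gives 34.3 ug/mL in this assay, so an at least 2.9-fold lower number from compound 1 to compound 2 (0.46 log units; beyond the scatter). Compound 3 `CCCCCCCCCCn1cc(-c2nc3ccccc3cc2CCC)nn1`, with a propyl group, again reaches only a limit in this assay, > 100 ug/mL. Hence an at least 2.9-fold higher number from compound 2 to compound 3 (0.46 log units; beyond the scatter), while a step that the two limits leave unreadable from compound 1 to compound 3 because of the limit of > 100 ug/mL in this assay, at which 2 of the 3 values shown sit. Compound 3 therefore stands at the limit, as compound 1 does. Compound 4 `CCCCCCCCCCn1cc(-c2nc3ccccc3cc2CCCCC)nn1` differs from compound 3 by ethyl in place of hydrogen on a saturated chain carbon, three bonds along the chain from an aromatic carbon. The two readable steps run in opposite directions, and the most recent chain extension raised the number, so a further extension is expected to leave compound 4 at or near the limit, a step that the limit leaves unreadable from compound 3 to compound 4. Compound 4 is estimated at 120 ug/mL, between 40 ug/mL and 300 ug/mL.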

Compound 4, half-maximal inhibitory concentration: 88 ug/mL
Beside the measured number, compound 4's estimate is 1.4-fold (0.13 log units) above it, within the range that was stated.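

In this assay pentyl yields a readable number, the second in this set, with a 2.6-fold higher number from compound 2 to compound 4 (0.41 log units; beyond the scatter), so ethyl keeps the lowest number of the four. The steps against the two compounds held at a limit read only as an at least 1.1-fold lower number from compound 3 to compound 4 (0.05 log units; that floor lies within the scatter) and an at least 1.1-fold lower number from compound 1 to compound 4 (0.05 log units; that floor lies within the scatter), so no order among methyl, propyl and pentyl can be told: the limit of > 100 ug/mL in this assay, at which 2 of the 4 values shown sit.

Going by these compounds, whether butyl in this place, or an amine or a carboxylic acid on this side chain, would bring the number close to that of ethyl stays open.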